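From compound 2 to the nitrile compound 3

The source may hold more compounds than are shown below. What is called first, only, known or untested is meant among the compounds shown, and "the series" means these compounds.

Measured so far in a functional assay (aorta) with Rattus norvegicus as the target, in the presence of a further agent that is not named here; a lower number here means that less compound is needed, a higher number that more compound is needed for the effect:
compound 1 `COC(=O)C1=C(C)N=C(C)/C(=C(/O)OC)C1c1ccccc1OCc1nonc1C(N)=O`: 970 nM
compound 2 `COC(=O)C1=C(C)N=C(C)/C(=C(/O)OC)C1c1ccccc1OCc1c(C(N)=O)no[n+]1[O-]`: 560 nM

Compound 2 gives 560 nM in this assay. Among the measured compounds shown here, the only other number available, that of compound 1, is 970 nM, and the two lie within the scatter of each other. Compound 3 `COC(=O)C1=C(C)N=C(C)/C(=C(/O)OC)C1c1ccccc1OCc1nonc1C#N` keeps the shared core and changes only the group on the chain: a group of 7 heavy atoms (3 carbon, 3 nitrogen, 1 oxygen; one five-membered aromatic ring with 3 hetero atoms) in place of a group of 9 heavy atoms (3 carbon, 3 nitrogen, 3 oxygen; one five-membered aromatic ring with 3 hetero atoms), on a saturated chain carbon bound to an oxygen on an aromatic ring. The entering group is 4-cyano-1,2,5-oxadiazol-3-yl.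

For the measured compounds named here, one measured step bears on this change: a 1.7-fold lower number from compound 1 to compound 2 (0.24 log units; within the scatter). It exchanged a group in the same place and stayed within the scatter. Going by the values given here, it is the only evidence, however, and no measured compound carries a nitrile, so the data do not speak to that group directly. On the strength of a 1.7-fold lower number from compound 1 to compound 2 (0.24 log units; within the scatter), no step beyond the scatter is expected in this assay, though the uncertainty is wide. The expected step is a 1.4-fold higher number from compound 2 to compound 3 (0.15 log units; within the scatter). For compound 3 the estimated value is 800 nM, with an expected range from 250 nM to 2500 nM.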

Compound 3, half-maximal effective concentration: 6.6 nM
For compound 3 the middle estimate is 120-fold (2.08 log units) above the measured one; the measured number lies below the stated range.
By their numbers in this assay, from the lowest: compound 3; then compounds 2 and 1 (each within the scatter of the next).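

In this assay the group on a saturated chain carbon bound to an oxygen on an aromatic ring proves able to shift the number far more than the earlier pair showed, since a 1.7-fold lower number from compound 1 to compound 2 (0.24 log units; within the scatter) stayed small while an 85-fold lower number from compound 2 to compound 3 (1.93 log units; beyond the scatter) is large. Among the compounds shown here, the plainest reading comes from a 150-fold lower number from compound 1 to compound 3 (2.17 log units; beyond the scatter) as the one step in which only cyano in place of carbamoyl on an aromatic carbon changes, and it shows that this single exchange on the ring is enough to carry a large step beyond the scatter. Compound 3 also stands apart from both other compounds by steps beyond the scatter, whereas those two remain within the scatter of each other. Nothing measured on these groups accompanies the result, and the numbers alone offer no explanation for the size of this step. Whether the gain belongs to the nitrile in particular stays open, as the compounds shown do not tell how a carboxylic acid, a methyl ester or an amine on the same aromatic carbon would behave. They also leave open how the nitrile would fare on the ring carried by compound 2.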